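This account rests on a few compounds, and the source may have more. Where it says the series, first, only, none or still open, it means among the compounds named here.

Measured in a physicochemical assay for solubility, read by turbidimetry, measured as kinetic solubility, at pH 7.4; on this read-out lower numbers stand for lower solubility and higher numbers for higher solubility:
- compound 1 `COc1ccc(F)cc1N1C(=O)CSC1c1cccc(C(=O)NCCCCn2cccn2)c1`: 50000 nM
- compound 2 `Cc1cccc(N2C(=O)CSC2c2cccc(C(=O)NCCCCc3ccccc3)c2)c1`: 10000 nM
- compound 3 `O=C(NCCCCc1ccccc1)c1cccc(C2SCC(=O)N2c2cccc(-c3c[nH]nn3)c2)c1`: 20000 nM

Compound 3 gives 20000 nM, which lies within the scatter of compound 2, while compound 1 gives a number higher than compound 3 by more than the scatter.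

Compound 4 `C#Cc1cccc(N2C(=O)CSC2c2cccc(C(=O)NCCCCc3ccccc3)c2)c1` has not been measured yet. The change leading to it is ethynyl in place of 1H-1,2,3-triazol-4-yl on an aromatic carbon, with ethynyl in place of 1H-1,2,3-triazol-4-yl on an aromatic carbon.

Among the measured compounds shown here, one measured step bears on this: a 2.0-fold higher number from compound 2 to compound 3 (0.30 log units; within the scatter), where the same 1H-1,2,3-triazol-4-yl replaced methyl. For the measured compounds named here, that step stayed within the scatter, and no measured compound carries ethynyl, so no change beyond the scatter is expected in this assay. The expected step is a 1.7-fold lower number from compound 3 to compound 4 (0.22 log units; within the scatter). For compound 4 the estimated value is 12000 nM, with an expected range from 5000 nM to 30000 nM.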

Compound 4, solubility: 10000 nM
The estimate for compound 4 lay 1.2-fold (0.08 log units) above the measured number; low and high end bracket the measured number.
By their numbers in this assay, from the lowest: compounds 2, 4 and 3 (each within the scatter of the next); then compound 1.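

At this aromatic carbon, ethynyl gives a 2.0-fold lower number from compound 3 to compound 4 (0.30 log units; within the scatter) in this assay. Set against methyl, the same group gives no change at the digits printed from compound 2 to compound 4 (within the scatter), so methyl, ethynyl and 1H-1,2,3-triazol-4-yl all read alike here, even though ethynyl has no ring and no hydrogen-bond donor while the triazolyl group has both. No supporting data explain this closeness. As far as these compounds go, whether an amine or a carboxylic acid on this carbon would move the number beyond the scatter remains open. So does whether these three groups would also read alike with a shorter chain in place of the phenylbutyl amide.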